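Benzothiophene Replaces Fluoropyridyl on the Shared Core

A few compounds are considered here, and "the series" means these few. Any claim that something is new, unique, unknown or untested is made for them only; others in the source may bear on it.

Measured so far in an ADME assay (liver) for metabolic stability, with Liver microsome (Homo sapiens) as the target, using microsomes and NADPH, with a stated time of 30 min, tested at 1 uM; on this read-out higher numbers stand for fast clearance and lower numbers for slow clearance:
Compound 1 `COc1cc(C(O)(C(F)(F)F)C(F)(F)F)cnc1N1CCN(S(=O)(=O)c2ccc(N)nc2)CC1` gives only a limit of the assay, < 14 mL.min-1.g-1.
Compound 2 `Nc1ccc(S(=O)(=O)N2CCN(c3ncc(C(O)(C(F)(F)F)C(F)(F)F)cc3C#CCO)CC2)cn1` also gives only a limit of the assay, < 14 mL.min-1.g-1.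
Compound 3 `Nc1ccc(S(=O)(=O)N2CCN(c3ncc(C(O)(C(F)(F)F)C(F)(F)F)cc3-c3cncc(F)c3)CC2)cn1` gives 24 mL.min-1.g-1.

Within the data shown here, compound 3 stands alone as the one compound with a real number; the other two rest at the limit of < 14 mL.min-1.g-1 in this assay, at which 2 of the 3 values shown sit, so it can only be said that compound 3 is cleared at least as fast as they are. The step of an at least 1.7-fold higher number from compound 1 to compound 3 (0.23 log units; that floor lies within the scatter) and the step of an at least 1.7-fold higher number from compound 2 to compound 3 (0.23 log units; that floor lies within the scatter) both start from a limit, so only a floor is known, and that floor lies within the scatter. The step that the two limits leave unreadable from compound 1 to compound 2 cannot be read at all.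

Compound 4 `Nc1ccc(S(=O)(=O)N2CCN(c3ncc(C(O)(C(F)(F)F)C(F)(F)F)cc3-c3cc4ccccc4s3)CC2)cn1` has not been measured. It differs from compound 3 by 1-benzothiophen-2-yl in place of 5-fluoropyridin-3-yl on an aromatic carbon. Among the measured compounds shown here, none of the measured steps swaps one aromatic ring group for another at this position, so the three compounds give no direct precedent; the only pattern is that the one substituent bearing a ring, in compound 3, carries the highest reading seen. On that slim basis compound 4 is expected to show a step of a 2.1-fold higher number from compound 3 to compound 4 (0.32 log units; beyond the scatter) in this assay, towards faster clearance. The estimate for compound 4 is 50 mL.min-1.g-1, with a range from 22 mL.min-1.g-1 to 115 mL.min-1.g-1.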

Compound 4, intrinsic clearance in microsomes: < 14 mL.min-1.g-1
Compound 4 gave a limit, no number; the forecaster's own chance of this, stated with the estimate: 5%; middle value at least 3.5-fold (0.55 log units) from the limit.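

Among these compounds, the only direct swap of one aromatic ring group for another on this aromatic carbon, 1-benzothiophen-2-yl in place of 5-fluoropyridin-3-yl, gives in this assay an at least 1.7-fold lower number from compound 3 to compound 4 (0.23 log units; that floor lies within the scatter); the reading for compound 4 is a limit of the assay, so only this floor is known. Carrying an aromatic ring group at this position therefore does not by itself go with a measurable clearance: compound 4 goes against the link between a ring and the highest reading that compound 3 had suggested. The steps from compound 1 and from compound 2 to compound 4 cannot be read, and compound 3 remains the only compound with a real number, while the others sit together: the limit of < 14 mL.min-1.g-1 in this assay, at which 3 of the 4 values shown sit.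

The compounds shown leave open whether the reading of compound 3 is tied to its ring nitrogen, its fluorine or the pyridine ring as a whole, and a plain phenyl ring at this carbon would help separate these. They also leave open how an amine or a carboxylic acid at this position would read, and how far apart the compounds at the limit truly lie.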